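A few compounds are considered here, and "the series" means these few. Any claim that something is new, unique, unknown or untested is made for them only; others in the source may bear on it.

Measured so far:
- compound 1 `CN(Cc1ccccc1)S(=O)(=O)c1cc(C(N)=O)c(NC(=O)c2ccn[nH]2)s1`: 1880 mL/min/kg
- compound 2 `Nc1cc(S(=O)(=O)N2CCC(OC(F)(F)F)CC2)cnc1C(=O)NCC(O)C(F)(F)F`: 300 mL/min/kg

In an ADME assay on microsomes from liver (Rattus norvegicus) for metabolic stability (a higher number here means faster removal of the compound, a lower number slower removal), compound 1 gives 1880 mL/min/kg, the higher of the two numbers. Compound 2 gives 300 mL/min/kg, and the gap between these two compounds lies beyond the usual scatter. These two compounds differ in more than one place, so their gap says nothing about any single change.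

Compound 3 `NC(=O)c1cc(S(=O)(=O)N2CCCCC2)sc1NC(=O)c1ccn[nH]1` has not yet been measured. It carries piperidin-1-yl in place of benzyl(methyl)amino on a sulfonyl sulfur. Among the compounds with values here, no measured pair shows this exchange, so the expectation is weakly grounded and the range is wide. With compound 1 at 1880 mL/min/kg, the top of the numbers seen so far, a move down seems more likely than a move up. The expected change is a 2.2-fold lower number from compound 1 to compound 3 (0.34 log units; beyond the scatter). For compound 3 the estimated value is 850 mL/min/kg, with an expected range of 300 mL/min/kg to 1900 mL/min/kg.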

Compound 3, clearance: 250 mL/min/kg
Estimate against measurement, compound 3: 3.4-fold (0.53 log units) above; measured number outside the range, below it.
By their numbers in this assay, from the lowest: compounds 3 and 2 (each within the scatter of the next); then compound 1.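

In this assay the exchange of benzyl(methyl)amino for piperidin-1-yl on a sulfonyl sulfur gives a 7.5-fold lower number from compound 1 to compound 3 (0.88 log units; beyond the scatter) with the rest of the core of compound 1 unchanged. Within the data shown here, this is the first single-place step, and it shows that the number responds strongly to the group on this sulfonyl sulfur. No measurement at hand gives a reason for the size of this step.

The exchange removes the six-membered aromatic ring of carbon only and brings in a six-membered non-aromatic ring in one move, so the two changes cannot be told apart. Also open, going by these compounds, is how the number responds to other groups on this sulfonyl sulfur, such as morpholine, pyrrolidine, dimethylamino or a piperidine carrying a hydroxyl group.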